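A few compounds are considered here, and "the series" means these few. Any claim that something is new, unique, unknown or untested is made for them only; others in the source may bear on it.

Measured so far:
compound 1 `COc1ccc2c(O[C@H]3C[C@H]4C(=O)N(C)CCCC/C=C/[C@@H]5C[C@@]5(C(=O)NS(=O)(=O)C5(C)CC5)NC(=O)N4C3)cc(-c3csc(C(F)(F)F)n3)nc2c1Cl` — 59000 nM
compound 2 `C#Cc1csc(-c2cc(O[C@H]3C[C@H]4C(=O)N(C)CCCC/C=C/[C@@H]5C[C@@]5(C(=O)NS(=O)(=O)C5CC5)NC(=O)N4C3)c3ccc(OC)c(C)c3n2)n1` — 14400 nM

Both numbers come from an ADME assay on Huh-7 cells (Homo sapiens) for cytotoxicity, read by colorimetric assay; a lower number here means that less compound is tolerated, a higher number that more compound is tolerated. Compound 1 stands highest of the two, and its gap to compound 2 lies beyond the usual scatter, but these two compounds differ at several places, so no single change can be read from them. Compound 3 `COc1ccc2c(O[C@H]3C[C@H]4C(=O)N(C)CCCC/C=C/[C@@H]5C[C@@]5(C(=O)NS(=O)(=O)C5(C)CC5)NC(=O)N4C3)cc(-c3nc(C#N)cs3)nc2c1Cl` arises from compound 1 by one change: 4-cyano-1,3-thiazol-2-yl in place of 2-(trifluoromethyl)-1,3-thiazol-4-yl on an aromatic carbon. Among the compounds with values here, no measured pair shows this change, so in this assay only a modest step is expected, leaning toward a somewhat lower number. The expected step is a 1.3-fold lower number from compound 1 to compound 3 (0.12 log units; within the scatter). Compound 3 is thus expected to give 45000 nM, within a range from 15000 nM to 100000 nM.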

Compound 3, half-maximal cytotoxic concentration: 75000 nM
Beside the measured number, compound 3's estimate is 1.7-fold (0.22 log units) below it, and the stated range covers the measured number.
By their numbers in this assay, from the lowest: compound 2; then compounds 1 and 3 (each within the scatter of the next).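

In this assay, the exchange of 2-(trifluoromethyl)-1,3-thiazol-4-yl for 4-cyano-1,3-thiazol-2-yl gives a 1.3-fold higher number from compound 1 to compound 3 (0.10 log units; within the scatter), which lies within the usual scatter. This position, next to the ring nitrogen, therefore accepts both substituted thiazoles with no readable difference in this measurement, even though the trifluoromethyl group gives way to a nitrile and the ring attachment also differs. Nothing available explains this result.

The compounds shown leave open whether an amine or a carboxylic acid on this thiazole would move the number. They also leave open whether a simple phenyl ring at this position would do so.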